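The compounds below may be only part of what the source reports. "The series", "measured", "known", "first", "only" and "open" are said of these compounds alone.

Working notes on the series. Compound 1 `N#CC1=C(NCC(=O)O)N(c2ccccc2)C(=O)N2CCCCC(N3CCCC3)C12` carries carboxymethyl on the amine nitrogen of the shared core; in a functional assay on the whole organism (strain albino) for inhibition, with Rattus norvegicus as the target, read by paw edema, with stated times of 1 h and 3 h, at a dose of 18 mmol/kg by the intraperitoneal route (a lower number here means a weaker effect, a higher number a stronger effect of the compound at the dose given), compound 1 gives 78.5%. Compound 2 `COC(=O)C(=O)NC1=C(C#N)C2C(N3CCCC3)CCCCN2C(=O)N1c1ccccc1` carries (methoxycarbonyl)carbonyl at the same nitrogen; in this assay compound 2 gives 86.2%. Among the measured compounds shown here, the one measured step, a number 7.7 percentage points higher from compound 1 to compound 2 (within the scatter), does not separate the two. Compound 2 thus holds the higher of the two numbers, though within the scatter of compound 1.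

Compound 3 `N#CC1=C(N)N(c2ccccc2)C(=O)N2CCCCC(N3CCCC3)C12` differs from compound 2 as follows: hydrogen in place of (methoxycarbonyl)carbonyl on an amine nitrogen. For the measured compounds named here, only the step from compound 1 to compound 2 touches this nitrogen, and it was within the scatter, so the amine substituent can change without a visible shift; no measured compound shows the bare amino group. The loss of the whole group is a larger change than that step, and the expected step is a number 16.2 percentage points lower from compound 2 to compound 3 (beyond the scatter), a modest fall in this assay. Compound 3 is therefore estimated at 70%, with a range of 45% to 88%.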

Compound 3, a percentage reported as inhibition, in the whole organism at one dose (the size of the read-out at that dose, not a potency): 79.5%
For compound 3 the middle estimate is 9.5 percentage points below the measured one, and the stated range covers the measured number.
By their numbers in this assay, from the lowest: compounds 1, 3 and 2 (each within the scatter of the next).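

The step to the bare amino group reads a number 6.7 percentage points lower from compound 2 to compound 3 (within the scatter), and the step from the carboxymethyl compound reads a number 1 percentage points higher from compound 1 to compound 3 (within the scatter), so in this assay neither substituent on this amine nitrogen is separated from plain hydrogen. The change from ((methoxycarbonyl)carbonyl)amino to amino removes 6 heavy atoms without a visible shift, which means that among these three compounds the read-out does not depend on a substituent at this nitrogen. No measurement bearing on the reason for this is available.

As far as these compounds go, whether the read-out stays level with a benzoyl group or a longer alkyl chain ending in an amine on this nitrogen remains open. Also open, from the compounds shown here alone, is whether the three compounds would still read alike at a lower dose.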